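From 4-isopropylphenyl to 3-methoxyphenyl on the amide-type nitrogen

A few compounds are considered here, and "the series" means these few. Any claim that something is new, unique, unknown or untested is made for them only; others in the source may bear on it.

Measured so far in a functional assay on MCF7 cells (Homo sapiens) for inhibition, read by MTT assay, with a stated time of 72 h; a higher number here means a weaker inhibitor, a lower number a stronger inhibitor
Compound 1 `CCc1ccc(NC(=O)C2CCN(C/C=C/c3ccccc3)CC2)cc1` gives 20000 nM
Compound 2 `CC(C)c1ccc(NC(=O)C2CCN(C/C=C/c3ccccc3)CC2)cc1` gives 9100 nM

For the measured compounds named here, compound 2 has the lower of the two numbers at 9100 nM and is therefore the stronger inhibitor of the pair, while compound 1 stands at 20000 nM in this assay as its only neighbour. Compound 3 `COc1cccc(NC(=O)C2CCN(C/C=C/c3ccccc3)CC2)c1` has not yet been measured. Relative to compound 2, it has 3-methoxyphenyl in place of 4-isopropylphenyl on an amide-type nitrogen. Going by the values given here, only one measured step bears on this change, and only loosely. It shows a 2.2-fold lower number from compound 1 to compound 2 (0.34 log units; beyond the scatter) and is modest, with methyl in place of hydrogen on a saturated chain carbon. Among the compounds with values here, no measured step involves a methoxy group, so the direction rests on little more than compound 3 lacking the 4-isopropylphenyl group of compound 2. A modest rise is expected, namely a 1.8-fold higher number from compound 2 to compound 3 (0.25 log units; within the scatter) in this assay as a tentative estimate. Compound 3 is estimated at 16000 nM (expected range 6000 nM to 40000 nM) in this assay once it is measured.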

Compound 3, half-maximal inhibitory concentration: 42700 nM
Beside the measured number, compound 3's estimate is 2.7-fold (0.43 log units) below it, outside the stated range (above it).
By their numbers in this assay, from the lowest: compound 2; then compound 1; then compound 3.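

On the amide-type nitrogen, the 3-methoxyphenyl group gives the weakest inhibitor of the three in this assay: the change shows a 4.7-fold higher number from compound 2 to compound 3 (0.67 log units; beyond the scatter) and, against the less favourable 4-ethylphenyl neighbour, still a 2.1-fold higher number from compound 1 to compound 3 (0.33 log units; beyond the scatter). The earlier pair showed only that this position responds to a small change within the 4-substituted phenyl groups, whereas compound 3 shows that a swap of the whole aryl group can move the number further, and in the opposite direction, with both steps beyond the scatter. Nothing at hand gives a reason for this loss.

The names 4-isopropylphenyl and 3-methoxyphenyl differ in both the group and its number, so the compounds shown cannot separate the two, and 4-methoxyphenyl or 3-isopropylphenyl would be needed to do so. Also open, on these data alone, is whether the gain from 4-ethylphenyl to 4-isopropylphenyl continues with 4-tert-butylphenyl, and how a carboxylic acid or an amine on this aromatic ring would read in this assay.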